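Swapping Fluoro for Trifluoromethyl on a Kinase Inhibitor

This account rests on a few compounds, and the source may have more. Where it says the series, first, only, none or still open, it means among the compounds named here.

Of the compounds shown here, two have been measured so far in an assay on isolated protein for inhibition of Rho-associated protein kinase 2 (Homo sapiens), read by radiometric assay and 33P incorporation, with a stated time of 40 min, in the presence of a further agent that is not named here; on this read-out higher numbers stand for weaker inhibition and lower numbers for stronger inhibition. Compound 1 `COc1cccc(Cn2cnc3sc(-c4ccc5[nH]ncc5c4)cc3c2=O)c1` gives 2 nM in this assay. Compound 2 `O=c1c2cc(-c3ccnc4[nH]ccc34)sc2ncn1Cc1cccc(F)c1` gives 1 nM. Compound 2 therefore shows the lower of the two numbers, but the gap to compound 1 is within the usual scatter of repeated measurements, so the two cannot be told apart on these data.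

The next compound, compound 3 `O=c1c2cc(-c3ccnc4[nH]ccc34)sc2ncn1Cc1cccc(C(F)(F)F)c1`, keeps the shared core of compound 2 and alters only the pendant aromatic ring: trifluoromethyl in place of fluoro on an aromatic carbon. For the measured compounds named here, no measured pair in this set shows the effect of this particular exchange, so nothing can be drawn from precedent here.

Given how close compound 1 and compound 2 sit, and that the exchange adds only a small group without changing ring, charge or hydrogen-bonding counts, a step from compound 2 to compound 3 of about a 2.0-fold higher number from compound 2 to compound 3 (0.30 log units; within the scatter) is expected, which would be at or near the limit of the scatter. Compound 3 is estimated at 2 nM, within a range from 0.5 nM to 8 nM.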

Compound 3, half-maximal inhibitory concentration: 7 nM
Beside the measured number, compound 3's estimate is 3.5-fold (0.54 log units) below it; the measured number falls inside the stated range.
By their numbers in this assay, from the lowest: compounds 2 and 1 (each within the scatter of the next); then compound 3.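

The aromatic carbon carrying this group is not indifferent to what sits on it: in this assay, trifluoromethyl in place of fluoro gives a 7.0-fold higher number from compound 2 to compound 3 (0.85 log units; beyond the scatter) and so weakens inhibition by a modest but real amount. The exchange goes from one heavy atom to four while adding no ring, no charge and no hydrogen-bond donor or acceptor, so a change this limited in those counts is enough to move the number, although compound 3 still gives 7 nM and remains a strong inhibitor on this read-out. Nothing available here accounts for the shift.

On these data alone, with only fluoro and trifluoromethyl compared on this otherwise unchanged scaffold, it remains open whether a methyl group, a chlorine, an amine or a carboxylic acid at this place would fall nearer to compound 2 or to compound 3, or beyond both. As far as these compounds go, it is also open whether the same exchange would cost as much at another carbon of this ring, or on a compound that carries the other groups of compound 1.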